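Compound 2 trades its chloro for 4-bromophenoxy

The source may report more compounds than this note shows. Statements on the series, on what has been measured and on what is new or still open speak of the compounds shown alone.

Compound 1 `COc1ccc(/C=C/C(=O)/C=C/c2cc3ccccc3nc2Cl)cc1`, compound 2 `COc1ccc(/C=C/C(=O)/C=C/c2cc3ccccc3nc2Cl)c(OC)c1` and compound 3 `COc1cc(OC)c(/C=C/C(=O)/C=C/c2cc3ccccc3nc2Cl)c(OC)c1` share one core and differ only in their methoxy groups. In a functional assay on DU-145 cells (Homo sapiens) for cytotoxicity, read by MTT assay, with a stated time of 48 h (a higher number here means a weaker inhibitor, a lower number a stronger inhibitor), compound 1 gives > 10000 nM, which is a limit and not a number. Compound 2 gives > 10000 nM, also a limit. Compound 3 gives > 10000 nM, again a limit. Compound 2 therefore has no exact standing, and the series offers only (the limit of > 10000 nM in this assay, at which 3 of the 3 values shown sit).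

The two methoxy changes yield a step that the two limits leave unreadable from compound 1 to compound 2 and a step that the two limits leave unreadable from compound 2 to compound 3, so neither gives a size to carry forward. Both also lie away from the place that changes next. Compound 4 `COc1ccc(/C=C/C(=O)/C=C/c2cc3ccccc3nc2Oc2ccc(Br)cc2)c(OC)c1` keeps the methoxy groups of compound 2 and differs by 4-bromophenoxy in place of chloro on an aromatic carbon, with 4-bromophenoxy in place of chloro next to the ring nitrogen.

Among the measured compounds shown here, with no measured step at this place, only a tentative expectation is possible. The expected change in this assay is an at least 1.6-fold lower number from compound 2 to compound 4 (0.22 log units; that floor lies within the scatter), a modest move toward stronger inhibition. Compound 4 is estimated at 6000 nM, with an expected range of 1500 nM to 20000 nM.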

Compound 4, half-maximal inhibitory concentration: > 10000 nM
Compound 4 was reported as a limit; the forecaster's own chance of this, stated with the estimate: 40%; middle value at least 1.6-fold (0.22 log units) away from the limit.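

Compound 2 and compound 4 both stand only as limits in this assay, so no step can be read between them: the limit of > 10000 nM in this assay, at which 4 of the 4 values shown sit.

What 4-bromophenoxy in place of chloro does to the number stays open, as does any ranking among the compounds shown.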